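Hydroxy for fluoro on the piperidine aryl of compound 2

The source may hold more compounds than are shown below. What is called first, only, known or untested is meant among the compounds shown, and "the series" means these compounds.

Measured in a functional assay on HEK293 cells for agonist activity at D(4) dopamine receptor (Homo sapiens), read by FLIPR; on this read-out lower numbers stand for an effect already at smaller amounts and higher numbers for an effect only at larger amounts of compound:
compound 1, `O=C(NCN1CCC(c2cccc[n+]2[O-])CC1)c1ccccc1`: 532 nM
compound 2, `Cc1cccc(NC(=O)CN2CCC(c3cccc(F)c3)CC2)c1`: 512 nM
compound 3, `O=C(NCN1CCC(c2cccc[n+]2[O-])CC1)c1ccc(F)c(Cl)c1`: 63 nM

Compound 2 stands second highest of the three numbers in this assay: its value lies within the scatter of that of compound 1, and well above that of compound 3, which differs from it beyond the scatter. Among the compounds with values here, the only single-point step among the measured compounds is an 8.4-fold lower number from compound 1 to compound 3 (0.93 log units; beyond the scatter), and that change sits on the carbonyl-side aryl, while compound 1 and compound 3 carry a different core from compound 2.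

Compound 4, `Cc1cccc(NC(=O)CN2CCC(c3cccc(O)c3)CC2)c1`, differs from compound 2 by hydroxy in place of fluoro on an aromatic carbon; read one bond further out, the change is 3-fluorophenyl to 3-hydroxyphenyl. Within the data shown here, no measured step touches this part of the molecule, so nothing in the data points to a direction. Compound 4 is therefore expected to give 700 nM in this assay, with a range of 150 nM to 3000 nM. The estimated step of a 1.4-fold higher number from compound 2 to compound 4 (0.14 log units; within the scatter) is expected to stay within the scatter, with a wide band to either side.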

Compound 4, half-maximal effective concentration: 8 nM
Beside the measured number, compound 4's estimate is 88-fold (1.94 log units) above it; the measured number lies below the stated range.
By their numbers in this assay, from the lowest: compound 4; then compound 3; then compounds 2 and 1 (each within the scatter of the next).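

In this assay, the place that holds the fluoro of compound 2 proves highly sensitive to the group on it: hydroxy in place of fluoro gives a 64-fold lower number from compound 2 to compound 4 (1.81 log units; beyond the scatter), a large step from exchanging one heavy atom for another. Within the data shown here, the only earlier step lay on the carbonyl-side aryl of a different core, so this is the first sign that the 3-substituted phenyl also governs the read-out, and here the entering group adds a hydrogen-bond donor and a hydrogen-bond acceptor by count. Nothing available bears on why this step is so large.

The compounds shown do not tell whether a methoxy, an amine or a hydroxymethyl group at the same place would match hydroxy. They also leave open whether hydroxy would give a similar step on the core of compound 1.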